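Amino in place of methyl: an antiproliferative estimate

The source may report more compounds than this note shows. Statements on the series, on what has been measured and on what is new or still open speak of the compounds shown alone.

Among the compounds with values here, in a functional assay on A549 cells (Homo sapiens) for antiproliferative activity, read by MTT assay, with a stated time of 48 h (on this read-out lower numbers stand for stronger inhibition and higher numbers for weaker inhibition), compound 2 `COc1cc(-c2cccc3nc(-c4ccc(C)cc4)oc23)cc(OC)c1OC` gives 680 nM, the lower of the two numbers so far, against compound 1 `COc1cc(-c2cccc3nc(-c4ccc(F)cc4)oc23)cc(OC)c1OC` at 8700 nM. Compound 3 `COc1cc(-c2cccc3nc(-c4ccc(N)cc4)oc23)cc(OC)c1OC` has amino in place of methyl on an aromatic carbon, para to a large group: amino in place of methyl on an aromatic carbon. Within the data shown here, only one measured step bears on this, a 13-fold lower number from compound 1 to compound 2 (1.11 log units; beyond the scatter), a large step with methyl in place of fluoro at that same place. That step does not involve amino, so it gives no direction, and no shift beyond the scatter is expected at the centre: the expected step is a 1.4-fold lower number from compound 2 to compound 3 (0.13 log units; within the scatter). Compound 3 is estimated at 500 nM, with a wide range of 90 nM to 3500 nM.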

Compound 3, half-maximal inhibitory concentration: 720 nM
Compound 3: middle estimate off by 1.4-fold (0.16 log units), on the low side; measured number inside the range.
By their numbers in this assay, from the lowest: compounds 2 and 3 (each within the scatter of the next); then compound 1.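

Amino brings a hydrogen-bond donor and a hydrogen-bond acceptor that methyl lacks, yet in this assay this change gives a 1.1-fold higher number from compound 2 to compound 3 (0.02 log units; within the scatter) and so stays within the scatter. Set against fluoro, amino gives a 12-fold lower number from compound 1 to compound 3 (1.08 log units; beyond the scatter) at the same place, so methyl and amino stand level there while fluoro alone stands apart. Nothing available offers an explanation for this result.

The compounds shown leave open how a hydroxyl or a dimethylamino group would read at this place. They also leave open whether chloro would stand with fluoro or with methyl and amino.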